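The compounds below may be only part of what the source reports. "The series", "measured", "known", "first", "only" and "open" are said of these compounds alone.

Measured compounds in a functional assay on A549 cells (Homo sapiens) for cytotoxicity, read by MTT assay, with a stated time of 72 h; a higher number here means a weaker inhibitor, a lower number a stronger inhibitor:
Compound 1, `CNC(=O)c1cc(Oc2ccc(NC(=O)c3nn(-c4ccc(Br)cc4F)c(=O)cc3C)cc2F)ccn1`, gives 7930 nM.
Compound 2, `Cc1cc(=O)n(-c2ccccc2C(F)(F)F)nc1C(=O)Nc1ccc(Oc2ncnc3ccsc23)cc1`, gives 8850 nM.
Compound 3, `Cc1cc(=O)n(-c2ccccc2OC(F)(F)F)nc1C(=O)Nc1ccc(Oc2ncnc3ccsc23)cc1`, gives 10100 nM.

Compound 3 carries the highest of the three numbers in this assay; its nearest neighbour is compound 2 and its furthest is compound 1, and both gaps sit within the scatter, so no order among the three can be read from these values. Going by the values given here, the only step between compounds differing in one place, a 1.1-fold higher number from compound 2 to compound 3 (0.06 log units; within the scatter), trifluoromethoxy in place of trifluoromethyl on an aromatic carbon, moved nothing beyond the scatter.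

Compound 4 is `Cc1cc(=O)n(-c2ccc(F)cc2)nc1C(=O)Nc1ccc(Oc2ncnc3ccsc23)cc1`. The change from compound 3 is 4-fluorophenyl in place of 2-(trifluoromethoxy)phenyl on an aromatic nitrogen. Among the compounds with values here, no measured step bears directly on this change: the one step available swaps two groups on the same phenyl and stays within the scatter, and compound 1, which carries a different phenyl on the aromatic nitrogen together with a different amide side, lies within the scatter of compound 3 as well. With all three measured values inside one band, the step of a 1.2-fold lower number from compound 3 to compound 4 (0.07 log units; within the scatter) is expected to remain within the scatter. Compound 4 is therefore estimated at 8500 nM in this assay, with a range from 3500 nM to 21000 nM.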

Compound 4, half-maximal inhibitory concentration: 2360 nM
For compound 4 the middle estimate is 3.6-fold (0.56 log units) above the measured one, outside the stated range (below it).
By their numbers in this assay, from the lowest: compound 4; then compounds 1, 2 and 3 (each within the scatter of the next).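

In this assay, going by these compounds alone, the group on the aromatic nitrogen is the first place where a single change moves the number beyond the scatter: a 4.3-fold lower number from compound 3 to compound 4 (0.63 log units; beyond the scatter) with 4-fluorophenyl in place of 2-(trifluoromethoxy)phenyl and a 3.8-fold lower number from compound 2 to compound 4 (0.57 log units; beyond the scatter) with 4-fluorophenyl in place of 2-(trifluoromethyl)phenyl. Both steps are modest and run the same way, whereas the exchange of trifluoromethyl for trifluoromethoxy on the same phenyl stayed within the scatter, so among these compounds this position responds to replacing the whole substituted phenyl and not to the choice between those two groups. Nothing at hand accounts for the lower number of compound 4.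

Each step removes one substituent and introduces fluorine at another place on the phenyl, so the two contributions cannot be separated here; unsubstituted phenyl would bear on that question, as would an amine or a carboxylic acid on the same ring for the range of groups tolerated. Going by these compounds, whether 4-fluorophenyl has the same effect on the other side of the amide, as in the different side carried by compound 1, also remains open.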